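A few compounds are considered here, and "the series" means these few. Any claim that something is new, unique, unknown or untested is made for them only; others in the source may bear on it.

Of the compounds shown here, three sharing one core have been measured in a functional assay on LoVo cells (Homo sapiens) for inhibition, read by MTT assay, with a stated time of 72 h; on this read-out higher numbers stand for weaker inhibition and lower numbers for stronger inhibition. Compound 1 (`C=C(Br)C(=O)Nc1cccc(/C=C/C(=O)Nc2ccc(F)cc2)c1`) carries a fluoro group and gives 4800 nM. Compound 2 (`C=C(Br)C(=O)Nc1cccc(/C=C/C(=O)Nc2ccc(OC)cc2)c1`) has methoxy in its place and gives 550 nM, while compound 3 (`C=C(Br)C(=O)Nc1cccc(/C=C/C(=O)Nc2ccc(OCC)cc2)c1`) has ethoxy and gives 850 nM. Compound 3 therefore sits level with compound 2, as a 1.5-fold higher number from compound 2 to compound 3 (0.19 log units; within the scatter) shows, and clearly under compound 1.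

The next compound is compound 4 (`C=C(Br)C(=O)Nc1cccc(/C=C/C(=O)Nc2ccc(OC(F)(F)F)cc2)c1`), which differs from compound 3 as follows: trifluoromethyl in place of ethyl on an oxygen on an aromatic ring. In words, this is trifluoromethyl in place of ethyl on an oxygen on an aromatic ring, or ethoxy to trifluoromethoxy.

Among the compounds with values here, no measured step makes this exact change, so the evidence is indirect. Two modest steps lead away from fluoro: an 8.7-fold lower number from compound 1 to compound 2 (0.94 log units; beyond the scatter) and a 5.6-fold lower number from compound 1 to compound 3 (0.75 log units; beyond the scatter). Within the data shown here, the only measured compound bearing fluorine, compound 1, has the highest number, 4800 nM. Compound 4 keeps the oxygen of compound 3 but also brings in fluorine, so it is expected to land between these two, though one compound is thin support. The expected change is a 1.8-fold higher number from compound 3 to compound 4 (0.25 log units; within the scatter), a modest move towards weaker inhibition. The estimate for compound 4 is 1500 nM, with an expected range from 500 nM to 4500 nM.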

Compound 4, half-maximal inhibitory concentration: 30300 nM
Beside the measured number, compound 4's estimate is 20-fold (1.31 log units) below it; the whole stated range lies below it.
By their numbers in this assay, from the lowest: compounds 2 and 3 (each within the scatter of the next); then compound 1; then compound 4.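

Until now, the groups joined through oxygen at this position looked interchangeable, as methoxy and ethoxy gave values within the scatter of each other and both gave stronger inhibition than fluoro. In this assay, replacing ethyl with trifluoromethyl on the same oxygen gives a 36-fold higher number from compound 3 to compound 4 (1.55 log units; beyond the scatter), and the matching comparison with the methoxy compound gives a 55-fold higher number from compound 2 to compound 4 (1.74 log units; beyond the scatter), so the group on this oxygen can matter far more than the methyl-to-ethyl step suggested. Trifluoromethoxy also falls behind fluoro, with a 6.3-fold higher number from compound 1 to compound 4 (0.80 log units; beyond the scatter), which makes compound 4 the weakest of the four and shows that an oxygen at this place does not by itself bring the stronger inhibition seen for compound 2 and compound 3.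

No measurement here accounts for this sharp loss of inhibition. Going by these compounds, whether the loss requires all three fluorines remains open, and so does the result of placing difluoromethyl or a longer chain such as propyl on the same oxygen.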